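The source may report more compounds than this note shows. Statements on the series, on what has been measured and on what is new or still open speak of the compounds shown alone.

Measured so far:

Compound 1 `CC(C)[C@H](NC(=O)COc1cccc2ccccc12)C(=O)N[C@@H](CC(=O)O)C(=O)CSc1nc[nH]n1` gives in a functional assay on Jurkat cells (Homo sapiens) for inhibition (a higher number here means a weaker inhibitor, a lower number a stronger inhibitor), a value of > 200000 nM, which is a limit of the assay and not a number.

Compound 2 `CC(C)[C@H](NC(=O)COc1cccc2ccccc12)C(=O)N[C@@H](CC(=O)O)C(=O)COn1nnc2ccccc21` gives in this assay a value of > 200000 nM, again a limit rather than a number.

Compound 3 `Cc1cc(OCC(=O)[C@H](CC(=O)O)NC(=O)[C@@H](NC(=O)COc2cccc3ccccc23)C(C)C)nc(C)n1` gives in this assay a value of > 200000 nM, also a limit.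

All three compounds share the same core and differ only in the group attached on the saturated chain carbon bound to a carbonyl carbon. Compound 3 therefore stands at the limit of > 200000 nM in this assay, at which 3 of the 3 values shown sit, alongside the other two, and no ordering among them can be read.

The step to compound 4 `CC(C)[C@H](NC(=O)COc1cccc2ccccc12)C(=O)N[C@@H](CC(=O)O)C(=O)COc1nccc2ccccc12` changes that same position: isoquinolin-1-yl in place of 2,6-dimethylpyrimidin-4-yl on an oxygen on a saturated carbon. Among the measured compounds shown here, the steps that bear on this place are a step that the two limits leave unreadable from compound 2 to compound 3 and a step that the two limits leave unreadable from compound 1 to compound 3, and both sit between two limits, so their sizes are unknown. With three changes at this position all leaving the value beyond the limit, no direction beyond the scatter can be predicted for this assay.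

Compound 4 is expected to give an estimated 200000 nM, with an estimated range from 50000 nM to 1000000 nM. The estimated step of a number no higher from compound 3 to compound 4 (the limit leaves the size open) is expected to be no real change, most likely another limit.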

Compound 4, half-maximal inhibitory concentration: 106000 nM
Compound 4: middle estimate off by 1.9-fold (0.28 log units), on the high side, and the stated range covers the measured number.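

In this assay, among the compounds shown here, compound 4 gives 106000 nM, the only value at this position so far that is a number rather than a limit, so (isoquinolin-1-yl)oxy on the saturated chain carbon bound to a carbonyl carbon gives a reading inside the range of this assay. The result is an at least 1.8-fold lower number from compound 3 to compound 4 (0.27 log units; that floor lies within the scatter), an at least 1.8-fold lower number from compound 2 to compound 4 (0.27 log units; that floor lies within the scatter) and an at least 1.8-fold lower number from compound 1 to compound 4 (0.27 log units; that floor lies within the scatter); each of these is only a floor, and each floor lies within the usual scatter, so a real gain is not established and compound 4 remains a very weak inhibitor. The steps among compound 1, compound 2 and compound 3 cannot be read, and those three compounds remain at a limit of the assay: the limit of > 200000 nM in this assay, at which 3 of the 4 values shown sit.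

The compounds shown leave open which part of isoquinolin-1-yl matters, and a plain phenyl on the same oxygen would begin to separate the carbon-only ring from the ring that holds the nitrogen. They also leave open whether any group at this position can bring the number far lower, or whether changes elsewhere on the shared core would be needed.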